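This account rests on a few compounds, and the source may have more. Where it says the series, first, only, none or still open, it means among the compounds named here.

Measured in an ADME assay on L02 cells (Homo sapiens) for cytotoxicity, read by MTT assay, with a stated time of 24 h; on this read-out higher numbers stand for weaker inhibition and lower numbers for stronger inhibition:
- compound 1 `COc1cc(/C=C2\CN(S(=O)(=O)c3ccc(NC(C)=O)cc3)C/C(=C\c3cc(OC)c(OC)c(OC)c3)C2=O)cc(OC)c1OC`: 13600 nM
- compound 2 `COc1cc(/C=C2\CN(S(=O)(=O)c3ccc(F)cc3)C/C(=C\c3cc(OC)c(OC)c(OC)c3)C2=O)cc(OC)c1`: 12300 nM
- compound 3 `COc1cc(/C=C2\CN(S(=O)(=O)c3ccc(NC(C)=O)cc3)C/C(=C\c3cccc([N+](=O)[O-])c3)C2=O)cc(OC)c1OC`: 15600 nM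

Compound 3 gives 15600 nM, which lies within the scatter of both compound 1 and compound 2, so no order can be read among the three.

The next structure is compound 4 `COc1cc(/C=C2\CN(S(=O)(=O)c3ccc(NC(C)=O)cc3)C/C(=C\c3cc(OC)c(OC)c(OC)c3)C2=O)cc(OC)c1`, and the change from compound 3 is 3,5-dimethoxyphenyl in place of 3-nitrophenyl on a double-bonded chain carbon bound to a double-bonded ring carbon. It places 3,5-dimethoxyphenyl in place of 3-nitrophenyl on a double-bonded chain carbon bound to a double-bonded ring carbon.

Among the compounds with values here, one measured step bears directly on this place: a 1.1-fold higher number from compound 1 to compound 3 (0.06 log units; within the scatter). That exchange of 3-nitrophenyl for 3,4,5-trimethoxyphenyl shows no separation. Compound 2 also carries 3,5-dimethoxyphenyl and gives 12300 nM, but it differs from compound 4 elsewhere too, so it offers only loose support.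

No step beyond the scatter is therefore expected in this assay. The expected size is a 1.1-fold lower number from compound 3 to compound 4 (0.05 log units; within the scatter). For compound 4 the estimated value is 14000 nM, with an expected range of 8500 nM to 23000 nM.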

Compound 4, half-maximal inhibitory concentration: 15900 nM
Compound 4: the middle estimate sits 1.1-fold (0.06 log units) below what was measured; measured number inside the range.
By their numbers in this assay, from the lowest: compounds 2, 1, 3 and 4 (each within the scatter of the next).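

In this assay, 3,5-dimethoxyphenyl in place of 3-nitrophenyl on a double-bonded chain carbon bound to a double-bonded ring carbon gives a 1.0-fold higher number from compound 3 to compound 4 (0.01 log units; within the scatter), and hydrogen in place of methoxy on an aromatic carbon of that group gives a 1.2-fold higher number from compound 1 to compound 4 (0.07 log units; within the scatter), so neither exchange separates from the scatter with the acetamido group held constant. Acetamido in place of fluoro on an aromatic carbon, a change at a second place, gives a 1.3-fold higher number from compound 2 to compound 4 (0.11 log units; within the scatter), which is also no separation. No evidence is at hand that would explain these results.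

As far as these compounds go, whether an amine, a carboxylic acid or a longer chain at the double-bonded chain carbon would give a step beyond the scatter stays open. The same question stands for such groups in place of acetamido on the aromatic carbon.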